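Vinyl in Place of 3-Chloropropyl on the Shared Core

This account rests on a few compounds, and the source may have more. Where it says the series, first, only, none or still open, it means among the compounds named here.

Among the measured compounds shown here, in a functional assay on MCF7 cells (Homo sapiens) for inhibition (on this read-out lower numbers stand for stronger inhibition and higher numbers for weaker inhibition), compound 1 `CCCCCC[C@@]1(C)SC(=O)C=C1OCC(=O)OCC` gives 14.2 ug/mL and compound 2 `CCCCCC[C@@]1(C)SC(=O)C=C1OCCCCCl` gives 8.6 ug/mL, so compound 2 stands within the scatter of the only other measured compound. Compound 3 `C=CCOC1=CC(=O)S[C@]1(C)CCCCCC` differs from compound 2 by vinyl in place of 3-chloropropyl on a saturated chain carbon bound to an oxygen on an unsaturated carbon, with vinyl in place of 3-chloropropyl on a saturated chain carbon bound to an oxygen on an unsaturated carbon. For the measured compounds named here, the sole measured step, a 1.7-fold lower number from compound 1 to compound 2 (0.22 log units; within the scatter), changed the group at this same place, so no step beyond the scatter is expected in this assay. The expected step is a 1.3-fold higher number from compound 2 to compound 3 (0.11 log units; within the scatter). Compound 3 is estimated at 11 ug/mL, with an expected range of 5 ug/mL to 24 ug/mL.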

Compound 3, half-maximal inhibitory concentration: > 50 ug/mL
Compound 3 ended at the assay's limit (the forecaster's own chance of this, stated with the estimate: 5%); middle value at least 4.5-fold (0.65 log units) from the limit.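

The earlier pair left this position looking tolerant, but in this assay vinyl in place of 3-chloropropyl gives an at least 5.8-fold higher number from compound 2 to compound 3 (0.76 log units; beyond the scatter) and vinyl in place of ethoxycarbonyl gives an at least 3.5-fold higher number from compound 1 to compound 3 (0.54 log units; beyond the scatter) on this read-out. So the group at this place can move the number beyond the scatter, and 3-chloropropyl and ethoxycarbonyl both stand apart from vinyl here. The value of compound 3 is a limit and not a number: the limit of > 50 ug/mL in this assay, at which 1 of the 3 values shown sits. Going by these compounds, the true size of both steps therefore stays open. So does whether an amine, a carboxylic acid or a longer unsubstituted chain at this place would keep the read-out of compound 2.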